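Swapping Chloro for Fluoro on the Pendant Ring

The compounds below may be only part of what the source reports. "The series", "measured", "known", "first", "only" and "open" are said of these compounds alone.

Compound 1, `N#Cc1cccc(S(=O)(=O)c2cnc3cc(F)ccc3c2-c2cccc(Cl)c2)c1`, gives 0.99 mL/min in an ADME assay on microsomes from liver (Homo sapiens) for metabolic stability, tested at 2.5 uM; on this read-out lower numbers stand for slow clearance and higher numbers for fast clearance.
Compound 2, `Cc1ccc(S(=O)(=O)c2cnc3cc(F)ccc3c2-c2cccc(Cl)c2)cc1C`, gives 4.01 mL/min in this assay.
Compound 3, `O=S(=O)(c1ccc(F)c(Cl)c1)c1cnc2cc(F)ccc2c1-c1cccc(Cl)c1`, gives 0.66 mL/min in this assay.

Among these three numbers compound 1 stands second highest: its nearest neighbour is compound 3, a step within the scatter (a 1.5-fold lower number from compound 1 to compound 3 (0.18 log units; within the scatter)), and its furthest is compound 2 (a 4.1-fold higher number from compound 1 to compound 2 (0.61 log units; beyond the scatter)). The third measured step, a 6.1-fold lower number from compound 2 to compound 3 (0.78 log units; beyond the scatter), like the other two, concerns only the aryl group on the sulfonyl sulfur.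

Compound 4, `N#Cc1cccc(S(=O)(=O)c2cnc3cc(F)ccc3c2-c2cccc(F)c2)c1`, differs from compound 1 elsewhere: fluoro in place of chloro on an aromatic carbon. Among the measured compounds shown here, no measured step touches this ring, so the three steps do not bear directly on it; they only show that this set spans a modest range in this assay. With nothing in the data pointing either way, a step of no more than the usual scatter is expected, a 1.1-fold lower number from compound 1 to compound 4 (0.04 log units; within the scatter), and compound 4 is estimated at 0.9 mL/min, within 0.45 mL/min to 1.8 mL/min.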

Compound 4, intrinsic clearance in a liver preparation (reported as CLH), per the amount of preparation that the assay uses: 0.78 mL/min
Compound 4: the middle estimate sits 1.2-fold (0.06 log units) above what was measured, within the range that was stated.
By their numbers in this assay, from the lowest: compounds 3, 4 and 1 (each within the scatter of the next); then compound 2.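

In this assay, the 3-chlorophenyl of compound 1 and the 3-fluorophenyl of compound 4 cannot be told apart, with a 1.3-fold lower number from compound 1 to compound 4 (0.10 log units; within the scatter) as the step between them. This first reading at this ring shows that, with the 3-cyanophenyl held fixed on the sulfonyl sulfur, this halogen exchange stays inside the usual scatter, whereas two of the three steps at the sulfonyl aryl group lie beyond it. Nothing among the data given explains why the two halogens read alike.

The compounds shown leave open whether a methoxy group, an amine or a carboxylic acid on this ring would also stay within the scatter. They also leave open whether the same exchange would read alike with the 3,4-dimethylphenyl of compound 2 on the sulfonyl sulfur.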